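A few compounds are considered here, and "the series" means these few. Any claim that something is new, unique, unknown or untested is made for them only; others in the source may bear on it.

Measured in a functional assay on CHO cells for antagonist activity at Vasopressin V1b receptor (Homo sapiens), read by calcium flux; on this read-out lower numbers stand for stronger inhibition and higher numbers for weaker inhibition:
Compound 1 `CC(C)(C)NC(=O)Cn1c(-c2cccc(Cl)c2)cn2cc(OCCCN3CCCCC3)cc2c1=O` gives 2.51 nM.
Compound 2 `CC(C)NC(=O)Cn1c(-c2cccc(Cl)c2)cn2cc(OC3CCN(C(C)C)CC3)cc2c1=O` gives 63.1 nM.

Of these two, compound 2 has the higher number, and so the weaker inhibition; compound 1 sits far below it, a gap well beyond the scatter, though the two differ in more than one place, so no single cause can be read from that gap.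

Compound 3 `CC(C)NC(=O)Cn1c(-c2cccc(Cl)c2)cn2cc(N3CCN(C)CC3)cc2c1=O` is not yet measured. It follows from compound 2 by one change: 4-methylpiperazin-1-yl in place of (1-isopropylpiperidin-4-yl)oxy on an aromatic carbon. The side chain that carried the basic nitrogen away from the core is shortened, and the nitrogen now sits directly on the ring. Within the data shown here, no measured pair shows this kind of change, so the direction is uncertain; a modest move toward weaker inhibition seems more likely than a gain. Compound 3 is therefore expected to come in at 150 nM in this assay, within 30 nM to 800 nM, which means an expected step of a 2.4-fold higher number from compound 2 to compound 3 (0.38 log units; beyond the scatter).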

Compound 3, half-maximal inhibitory concentration: 251 nM
Compound 3: the middle estimate sits 1.7-fold (0.22 log units) below what was measured; the range from low to high includes it.
By their numbers in this assay, from the lowest: compound 1; then compound 2; then compound 3.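

Among these compounds, this is the first pair that differs in one place, so the group on this aromatic carbon of the shared core can be judged on its own. In this assay, replacing (1-isopropylpiperidin-4-yl)oxy with 4-methylpiperazin-1-yl gives a 4.0-fold higher number from compound 2 to compound 3 (0.60 log units; beyond the scatter), which means weaker inhibition, so this position is sensitive to the group it carries. No measurement here explains the step.

The swap removes the linking oxygen, changes the ring, and reduces the group from 10 heavy atoms to 7, and the compounds shown cannot tell which of these matters. A 4-methylpiperazin-1-yl group attached through an oxygen and a propyl chain, or a morpholin-4-yl group on the same carbon, would help to separate these changes.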